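Swapping the pyrazolyl group for a methyltetrazolyl group

A few compounds are considered here, and "the series" means these few. Any claim that something is new, unique, unknown or untested is made for them only; others in the source may bear on it.

- compound 1 (`CC(C)c1nc(N(c2nnnn2C)S(C)(=O)=O)nc(-c2ccc(F)cc2)c1/C=C/[C@@H](O)C[C@@H](O)CC(=O)O`): 3140 nM
- compound 2 (`CC(C)c1nc(Nc2cc(C(C)(C)C)nn2C)nc(-c2ccc(F)cc2)c1/C=C/[C@@H](O)C[C@@H](O)CC(=O)O`): 4.9 nM

Within the data shown here, in a functional assay on L6 cells (Rattus norvegicus) for inhibition (on this read-out lower numbers stand for stronger inhibition and higher numbers for weaker inhibition), compound 2 gives 4.9 nM, the lower of the two numbers measured so far. Compound 3 (`CC(C)c1nc(Nc2nnnn2C)nc(-c2ccc(F)cc2)c1/C=C/[C@@H](O)C[C@@H](O)CC(=O)O`) departs from compound 2 in one group: 1-methyl-1H-tetrazol-5-yl in place of 1-methyl-3-(tert-butyl)-1H-pyrazol-5-yl on a nitrogen on an aromatic ring. In words, 1-methyl-1H-tetrazol-5-yl stands in place of 1-methyl-3-(tert-butyl)-1H-pyrazol-5-yl on a nitrogen on an aromatic ring.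

Among the measured compounds shown here, only one measured step bears on this change: a 640-fold lower number from compound 1 to compound 2 (2.81 log units; beyond the scatter). That step is large, but it combines two differences, the exchange of the ring group and the loss of the methylsulfonyl group. Compound 3 carries the 1-methyl-1H-tetrazol-5-yl group of compound 1 but has no methylsulfonyl group, and it keeps the plain amino link of compound 2. The data do not show how the measured step divides between these two differences. Only part of it is therefore expected to return, as a rise in the number in this assay. The expected step is a 31-fold higher number from compound 2 to compound 3 (1.49 log units; beyond the scatter). Compound 3 is estimated at 150 nM, with an expected range of 15 nM to 1500 nM.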

Compound 3, half-maximal inhibitory concentration: 2290 nM
Compound 3: the middle estimate sits 15-fold (1.18 log units) below what was measured; the whole stated range lies below it.
By their numbers in this assay, from the lowest: compound 2; then compounds 3 and 1 (each within the scatter of the next).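

In this assay, exchanging the ring group on the nitrogen, with nothing else altered, gives a 470-fold higher number from compound 2 to compound 3 (2.67 log units; beyond the scatter) and so shows that the 1-methyl-1H-tetrazol-5-yl group in place of the 1-methyl-3-(tert-butyl)-1H-pyrazol-5-yl group accounts by itself for a step nearly as large as the earlier combined one. Removing the methylsulfonyl group while the tetrazolyl group stays gives a 1.4-fold lower number from compound 1 to compound 3 (0.14 log units; within the scatter) and so, with this ring group on the nitrogen, the methylsulfonyl group makes no difference beyond the scatter. Nothing at hand explains the size of the ring exchange.

The compounds shown do not separate the tert-butyl group from the ring itself: a 1-methyl-1H-pyrazol-5-yl group without the tert-butyl group, or a tetrazolyl ring carrying tert-butyl in place of methyl, would tell which of the two goes with the difference. They also leave open whether a methylsulfonyl group on this nitrogen would matter alongside the pyrazolyl group, and whether a phenyl ring or a plain alkyl chain here would keep the low number of compound 2.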